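From Carboxy to Methylcarbamoyl on Compound 2

The compounds below may be only part of what the source reports. "The series", "measured", "known", "first", "only" and "open" are said of these compounds alone.

In an ADME assay on the whole organism (plasma, Homo sapiens) for metabolic stability, read by LC-MS (a lower number here means that the compound disappears faster, a higher number that the compound lasts longer), compound 1 (`CN1CCc2nc(C(=O)N[C@@H]3C[C@@H](C(=O)N(C)C)CC[C@@H]3NC(=O)C(=O)O)sc2C1`) gives 6.9 h and compound 2 (`CN1CCc2nc(C(=O)N[C@@H]3C[C@@H](C(=O)O)CC[C@@H]3NC(=O)C(=O)Nc3ccc(Cl)cn3)sc2C1`) gives 8.2 h and the two sit within the scatter of each other. Compound 3 (`CNC(=O)[C@H]1CC[C@H](NC(=O)C(=O)Nc2ccc(Cl)cn2)[C@H](NC(=O)c2nc3c(s2)CN(C)CC3)C1`) has not yet been measured. It carries methylamino in place of hydroxy on a carbonyl carbon so carboxy becomes methylcarbamoyl. Among the compounds with values here, no measured pair shows this change alone, so compound 2 at 8.2 h is the only anchor. The estimated 1.0-fold lower number from compound 2 to compound 3 (0.01 log units; within the scatter) is expected to stay within the scatter in this assay with no clear direction. Compound 3 is expected to show 8 h (estimated range 4 h to 16 h) as its half-life.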

Compound 3, half-life: 9 h
The estimate for compound 3 lay 1.1-fold (0.05 log units) below the measured number; measured number inside the range.
By their numbers in this assay, from the lowest: compounds 1, 2 and 3 (each within the scatter of the next).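

In this assay, putting methylamino in place of hydroxy on a carbonyl carbon, which turns carboxy into methylcarbamoyl, gives a step within the scatter (a 1.1-fold higher number from compound 2 to compound 3 (0.04 log units; within the scatter)). Within the data shown here, this is the first direct reading of this change, and it shows that the half-life stays within the scatter when this acid group becomes an amide. Nothing measured here explains the result. Going by these compounds, whether ethylamino or a plain amino group on the same carbonyl carbon would also leave the half-life within the scatter remains open.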